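This account rests on a few compounds, and the source may have more. Where it says the series, first, only, none or still open, it means among the compounds named here.

Measured in a functional assay on HL-60 cells (Homo sapiens) for antiproliferative activity, read by CCK-8 assay, with a stated time of 72 h; on this read-out higher numbers stand for weaker inhibition and lower numbers for stronger inhibition:
- compound 1 `Cc1cc(Nc2cc(N3CCN(C)CC3)nc(Nc3ccc([N+](=O)[O-])cc3)n2)n[nH]1`: 69.8 nM
- compound 2 `Cc1cc(Nc2cc(N3CCN(C)CC3)nc(Nc3ccc(Cl)cc3)n2)n[nH]1`: 83.4 nM
- compound 3 `Cc1cc(Nc2cc(N3CCN(C)CC3)nc(Nc3cccc([N+](=O)[O-])c3)n2)n[nH]1`: 90.9 nM

In this assay compound 3 gives 90.9 nM, which lies within the scatter of both other compounds, so the three values cannot be ranked. The next step leads to compound 4 `Cc1cc(Nc2cc(N3CCN(C)CC3)nc(Nc3ccc(C#N)cc3)n2)n[nH]1`. The change is 4-cyanophenyl in place of 3-nitrophenyl on a nitrogen on an aromatic ring, with 4-cyanophenyl in place of 3-nitrophenyl on a nitrogen on an aromatic ring.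

Going by the values given here, three measured steps bear on it: a 1.2-fold higher number from compound 1 to compound 2 (0.08 log units; within the scatter), a 1.3-fold higher number from compound 1 to compound 3 (0.11 log units; within the scatter) and a 1.1-fold higher number from compound 2 to compound 3 (0.04 log units; within the scatter). Two of these exchange the group on that same nitrogen, and all three stay within the scatter. Among the compounds with values here, no compound carrying a nitrile has been measured, so the expectation is an extrapolation from these small steps. No step beyond the scatter is expected in this assay, in either direction.

The expected step is a 1.1-fold lower number from compound 3 to compound 4 (0.06 log units; within the scatter), an estimate that stays within the scatter. For compound 4 the estimated value is 80 nM, with an expected range of 40 nM to 160 nM.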

Compound 4, half-maximal inhibitory concentration: 21.8 nM
Estimate against measurement, compound 4: 3.7-fold (0.56 log units) above, and the stated range ends above it.
By their numbers in this assay, from the lowest: compound 4; then compounds 1, 2 and 3 (each within the scatter of the next).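

Notes on the aryl group on the nitrogen: the earlier exchanges at this position all stayed within the scatter in this assay, and the 4-cyanophenyl group is the first to move the number beyond it (a 4.2-fold lower number from compound 3 to compound 4 (0.62 log units; beyond the scatter)). The gain is also seen in the two exchanges made on the aromatic carbon alone, with cyano in place of chloro (a 3.8-fold lower number from compound 2 to compound 4 (0.58 log units; beyond the scatter)) and cyano in place of nitro (a 3.2-fold lower number from compound 1 to compound 4 (0.51 log units; beyond the scatter)), so all three other compounds lie on the weaker side of compound 4. Nothing available accounts for this gain.

The compounds shown leave open whether the nitrile keeps this gain as 3-cyanophenyl. They also leave open whether a carboxamide or a trifluoromethyl group on the same aromatic carbon would match it.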